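Replacing tert-butyl with bromo in an antiproliferative series

This account rests on a few compounds, and the source may have more. Where it says the series, first, only, none or still open, it means among the compounds named here.

In a functional assay on HCT-116 cells (Homo sapiens) for antiproliferative activity, read by MTT assay, with a stated time of 72 h (a higher number here means a weaker inhibitor, a lower number a stronger inhibitor), three compounds have been measured so far. Compound 1 `NC1=NC2(CCOCC2)N(OCCCOc2ccccc2)C(N)=N1` gives 6010 nM there, and compound 3 `NC1=NC2(CCOCC2)N(OCCCOc2ccc(Cl)cc2)C(N)=N1` gives 690 nM on the same core. Compound 2 `CC(C)(C)c1ccc(OCCCON2C(N)=NC(N)=NC23CCSCC3)cc1` gives 1 nM on a different core, the lowest number of the three and beyond the scatter from both others.

The unmeasured compound 4 `NC1=NC2(CCSCC2)N(OCCCOc2ccc(Br)cc2)C(N)=N1` keeps the core of compound 2 and alters one group. The change is bromo in place of tert-butyl on an aromatic carbon and in words it is bromo in place of tert-butyl on an aromatic carbon, para to a large group.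

Among the measured compounds shown here, only one measured step bears on this, and it is modest: an 8.7-fold lower number from compound 1 to compound 3 (0.94 log units; beyond the scatter) with chloro in place of hydrogen on the other core. For the measured compounds named here, no measured step isolates the loss of tert-butyl. Compound 3 at 690 nM stands far above compound 2 at 1 nM but the two differ in core as well as group, so that gap cannot be divided between those two changes.

A step towards a weaker result, beyond the scatter, is therefore expected in this assay with its size poorly fixed. The estimated change is a 40-fold higher number from compound 2 to compound 4 (1.60 log units; beyond the scatter) in that direction. Compound 4 is expected at 40 nM within a range of 4 nM to 400 nM on this estimate.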

Compound 4, half-maximal inhibitory concentration: 20 nM
Compound 4: middle estimate off by 2.0-fold (0.30 log units), on the high side; measured number inside the range.
By their numbers in this assay, from the lowest: compound 2; then compound 4; then compound 3; then compound 1.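

In this assay, among the compounds shown here, setting bromo in place of tert-butyl on the core of compound 2 gives a 20-fold higher number from compound 2 to compound 4 (1.30 log units; beyond the scatter), the first measured step that isolates a change at this place, on an aromatic carbon para to a large group. It shows that the number on this core depends strongly on the group held there, and that the step is larger than the only earlier one, an 8.7-fold lower number from compound 1 to compound 3 (0.94 log units; beyond the scatter), although that step concerns another core and another exchange, so the two sizes show no shared rule. With one heavy atom in place of four, compound 4 still gives 20 nM, but nothing given here accounts for the size of this step.

The compounds shown leave open how an amine, a methoxy group or a longer alkyl chain at this place on the core of compound 2 would compare with tert-butyl and bromo, and whether the number follows the size of the group at all. For the compounds shown here, they also leave the contribution of the core undivided, as no pair here differs in the core alone.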